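The source may report more compounds than this note shows. Statements on the series, on what has been measured and on what is new or still open speak of the compounds shown alone.

Measured in a functional assay on HOP-62 cells (Homo sapiens) for inhibition, read by sulforhodamine B assay; a higher number here means a weaker inhibitor of growth, a lower number a stronger inhibitor of growth:
compound 1 `c1ccc(-c2ccc(-c3ccc(-c4nc5ccccc5[nH]4)cc3)cc2)cc1` gives 100000 nM
compound 2 `FC(F)(F)c1ccc(-c2ccc(-c3ccc(-c4nc5ccccc5[nH]4)cc3)cc2)cc1` gives 100000 nM
compound 3 `CN(C)c1ccc(-c2ccc(-c3ccc(-c4nc5ccccc5[nH]4)cc3)cc2)cc1` gives 100000 nM

Compounds 1 and 2 stand level with compound 3 at 100000 nM, so the three measured compounds show no separation in this assay.

The compound still to be measured is compound 4 `COc1ccc(-c2ccc(-c3ccc(-c4nc5ccccc5[nH]4)cc3)cc2)cc1OC`, which keeps the shared core and differs from compound 3 as follows: 3,4-dimethoxyphenyl in place of 4-(dimethylamino)phenyl on an aromatic carbon.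

Among the measured compounds shown here, three measured steps bear on this change. They are no change at the digits printed from compound 1 to compound 2 (within the scatter), no change at the digits printed from compound 1 to compound 3 (within the scatter) and no change at the digits printed from compound 2 to compound 3 (within the scatter). The last of these is the closest, as it also exchanges the dimethylamino group. None of the three steps moved the value, but none of them involves a methoxy group, so the read-across is indirect.

On that basis, no step beyond the scatter is expected in this assay, and the expected size is a 1.3-fold lower number from compound 3 to compound 4 (0.10 log units; within the scatter). The estimate for compound 4 is 80000 nM, with an expected range of 25000 nM to 100000 nM.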

Compound 4, concentration for 50% growth inhibition: 4200 nM
Compound 4: the middle estimate sits 19-fold (1.28 log units) above what was measured, outside the stated range (below it).
By their numbers in this assay, from the lowest: compound 4; then compounds 1, 2 and 3 (each within the scatter of the next).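

In this assay, this position no longer looks silent: 3,4-dimethoxyphenyl gives a large step against phenyl (a 24-fold lower number from compound 1 to compound 4 (1.38 log units; beyond the scatter)), against 4-(trifluoromethyl)phenyl (a 24-fold lower number from compound 2 to compound 4 (1.38 log units; beyond the scatter)) and against 4-(dimethylamino)phenyl (a 24-fold lower number from compound 3 to compound 4 (1.38 log units; beyond the scatter)). The three earlier groups stood level and gave no sign that a change here could move the number, so the series is sensitive at this position to at least one substituent pattern. Nothing available accounts for the step.

As far as these compounds go, it remains open whether the step needs both methoxy groups or whether a single methoxy group would carry it. A hydroxyl group or a longer ethoxy chain in their place would test how specific the dimethoxy pattern is.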